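Working notes: amino versus alkoxy variants at one ring position

This account rests on a few compounds, and the source may have more. Where it says the series, first, only, none or still open, it means among the compounds named here.

Measured so far:
compound 1 `Cn1ncc2c(-c3ccc(F)cc3)cc(NNC(=O)Nc3cc(Cl)nc(OCCF)c3)nc21` gives 2790 nM in an assay on isolated protein for binding affinity to sphingosine 1-phosphate receptor 2 (Homo sapiens), read by surface plasmon resonance; a higher number here means weaker binding, a lower number tighter binding
compound 2 `CCN(CC)c1cc(NC(=O)NNc2cc(-c3ccc(F)cc3)c3cnn(C)c3n2)cc(Cl)n1` gives 3150 nM in this assay
compound 3 `COc1ccc(-c2cc(NNC(=O)Nc3cc(Cl)nc(Cl)c3)nc3c2c(C)nn3C)cc1` gives 1020 nM in this assay

Compound 2 stands at the weak end of the three numbers in this assay; its gap to compound 1 is within the scatter, its gap to compound 3 beyond it. Compound 4 `COc1cc(NC(=O)NNc2cc(-c3ccc(F)cc3)c3cnn(C)c3n2)cc(Cl)n1` differs from compound 2 in one place: methoxy in place of diethylamino on an aromatic carbon. Within the data shown here, the only step that bears on this is a 1.1-fold higher number from compound 1 to compound 2 (0.05 log units; within the scatter), which exchanged one group at the same carbon for the one now leaving and moved the number within the scatter only. The change to methoxy is expected to behave likewise. Compound 4 is therefore estimated at 2800 nM, with a range of 1400 nM to 5600 nM, which means an expected step of a 1.1-fold lower number from compound 2 to compound 4 (0.05 log units; within the scatter) from compound 2 that should stay within the scatter.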

Compound 4, dissociation constant: 1650 nM
For compound 4 the middle estimate is 1.7-fold (0.23 log units) above the measured one; the range from low to high includes it.
By their numbers in this assay, from the lowest: compounds 3, 4, 1 and 2 (each within the scatter of the next, the first and the last beyond it).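

At this carbon next to the ring nitrogen, methoxy in place of diethylamino gives a 1.9-fold lower number from compound 2 to compound 4 (0.28 log units; within the scatter), and hydrogen in place of fluoromethyl on the saturated chain carbon bound to the oxygen gives a 1.7-fold lower number from compound 1 to compound 4 (0.23 log units; within the scatter). Diethylamino, 2-fluoroethoxy and methoxy therefore all lie within the scatter of one another here, so these three groups do not separate at this position. No measurement at hand accounts for this.

On these data alone, whether a carboxylic acid or a primary amine at this carbon would also stay within the scatter remains open. So does whether a longer chain, such as butoxy, would do so.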